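Exchanging the Piperidinyl Group on Compound 2

This account rests on a few compounds, and the source may have more. Where it says the series, first, only, none or still open, it means among the compounds named here.

Compound 1 `CC(C(=O)NCc1ccc(C(F)(F)F)nc1N(C)c1ccccc1)c1ccc(NS(C)(=O)=O)c(F)c1` gives 0.9 nM in a functional assay on CHO-K1 cells for antagonist activity at transient receptor potential cation channel subfamily V member 1 (Homo sapiens), read by FLIPR; on this read-out higher numbers stand for weaker inhibition and lower numbers for stronger inhibition.
Compound 2 `CC(C(=O)NCc1ccc(C(F)(F)F)nc1N1CCC(=O)CC1)c1ccc(NS(C)(=O)=O)c(F)c1` gives 91 nM in this assay.

Compound 2 stands at the higher of the two numbers, separated from compound 1 by a 100-fold higher number from compound 1 to compound 2 (2.00 log units; beyond the scatter). Compound 3 `CC(C(=O)NCc1ccc(C(F)(F)F)nc1N1CCC(CN(C)C)CC1)c1ccc(NS(C)(=O)=O)c(F)c1` differs from compound 2 by 4-((dimethylamino)methyl)piperidin-1-yl in place of 4-oxopiperidin-1-yl on an aromatic carbon. For the measured compounds named here, no measured step exchanges one piperidinyl group for another; the only measured step swaps methyl(phenyl)amino for 4-oxopiperidin-1-yl and bears on this change only loosely. Compound 3 is therefore expected near compound 2, with a step of a 1.3-fold higher number from compound 2 to compound 3 (0.12 log units; within the scatter) in this assay that is uncertain in direction. The estimate for compound 3 is 120 nM, within 25 nM to 600 nM.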

Compound 3, inhibition constant: 2.1 nM
Beside the measured number, compound 3's estimate is 57-fold (1.76 log units) above it, outside the stated range (below it).
By their numbers in this assay, from the lowest: compound 1; then compound 3; then compound 2.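

In this assay, a six-membered non-aromatic ring at this carbon next to the ring nitrogen does not by itself set the result: 4-((dimethylamino)methyl)piperidin-1-yl in place of 4-oxopiperidin-1-yl gives a 43-fold lower number from compound 2 to compound 3 (1.64 log units; beyond the scatter), so the substituent on that ring matters. Measured against methyl(phenyl)amino, the same group still leaves a 2.3-fold higher number from compound 1 to compound 3 (0.37 log units; beyond the scatter), a much smaller gap than a 100-fold higher number from compound 1 to compound 2 (2.00 log units; beyond the scatter). Nothing measured here accounts for these differences. On these data alone, it remains open whether the dimethylamino group itself matters, which a 4-methylpiperidin-1-yl or 4-(aminomethyl)piperidin-1-yl group could test.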